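This account rests on a few compounds, and the source may have more. Where it says the series, first, only, none or still open, it means among the compounds named here.

For the measured compounds named here, in a functional assay (brain) for inhibition, with Rattus norvegicus as the target (a lower number here means a stronger inhibitor, a higher number a weaker inhibitor), compound 3 `CCCCCCCCCCCCCCCCCCOC1=C(O)OC(C2COC(C)(C)O2)C1=O` gives 2400 nM, the lowest of the three numbers so far and beyond the scatter from the other two. Compound 1 `CCCCCCCCCCOC1=C(O)OC(C(O)CO)C1=O` gives 13000 nM, and compound 2 `CCCCCCCCCCCOC1=C(O)OC(C(O)CO)C1=O` gives 13000 nM. Going by the values given here, the only measured single change, methyl in place of hydrogen on the chain, shows no change at the digits printed from compound 1 to compound 2 (within the scatter).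

Compound 4 `CCCCCCCCCCCCCCCCCCOC1=C(O)OC(CCO)C1=O` keeps the long chain of compound 3 but swaps a group: 2-hydroxyethyl in place of 2,2-dimethyl-1,3-dioxolan-4-yl on a saturated ring carbon. Among the compounds with values here, the chain step says nothing direct about this swap, and no measured pair isolates it. Compounds 1 and 2 differ from compound 3 in both chain and group, so their gap cannot be divided between the two changes.

Compound 4 shares its chain with compound 3 and, like compounds 1 and 2, carries a free hydroxy group at that ring carbon, so a value between these numbers seems the likeliest outcome. The expected change is modest and upward, a 1.7-fold higher number from compound 3 to compound 4 (0.22 log units; within the scatter). For compound 4 the estimate is 4000 nM, with an expected range from 1200 nM to 13000 nM.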

Compound 4, half-maximal inhibitory concentration: 6800 nM
Estimate against measurement, compound 4: 1.7-fold (0.23 log units) below, and the stated range covers the measured number.
By their numbers in this assay, from the lowest: compound 3; then compounds 4, 1 and 2 (each within the scatter of the next).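

In this assay, putting 2-hydroxyethyl in place of 2,2-dimethyl-1,3-dioxolan-4-yl on a saturated ring carbon gives a 2.8-fold higher number from compound 3 to compound 4 (0.45 log units; beyond the scatter), so the number does respond to the group at this position. For the compounds shown here, this is the first pair that holds the long chain fixed and changes only this group; compounds 1 and 2 differ from compound 3 in both chain and group, and could not show this. Nothing measured here explains the shift.

As far as these compounds go, it remains open whether the hydroxy group of 2-hydroxyethyl matters at all, which an ethyl group, an amine or a carboxylic acid at this position on the same chain would help to test. Also open is what chain length does alone, as the 1,2-dihydroxyethyl group of compounds 1 and 2 is not shown on the long chain of compound 3.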